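The compounds below may be only part of what the source reports. "The series", "measured", "known", "first", "only" and "open" are said of these compounds alone.

In a functional assay on liver (Rattus norvegicus, strain Sprague-Dawley) for inhibition, with a stated time of 1 h (a higher number here means a weaker inhibitor, a lower number a stronger inhibitor), compound 1 `COc1ccc(C(=O)OCC2Oc3ccc([C@H]4Oc5cc(O)cc(O)c5C(=O)[C@@H]4O)cc3OC2c2ccc(O)c(OC)c2)cc1` gives 21000 nM and compound 2 `COc1cc(C2Oc3cc([C@H]4Oc5cc(O)cc(O)c5C(=O)[C@@H]4O)ccc3OC2COC(=O)c2ccc(N)cc2)ccc1O` gives 14300 nM, two values within the scatter of each other. Compound 3 `COc1cc(C2Oc3cc([C@H]4Oc5cc(O)cc(O)c5C(=O)[C@@H]4O)ccc3OC2COC(=O)c2cc(OC)c(OC)c(OC)c2)ccc1O` differs from compound 1 in one place, with 3,4,5-trimethoxyphenyl in place of 4-methoxyphenyl on a carbonyl carbon. Among the measured compounds shown here, the only measured step, a 1.5-fold lower number from compound 1 to compound 2 (0.17 log units; within the scatter), is amino in place of methoxy on an aromatic carbon, a different change that offers limited guidance. No shift beyond the scatter is therefore expected in this assay, and the estimated step is a 1.2-fold lower number from compound 1 to compound 3 (0.09 log units; within the scatter). Compound 3 is expected at 17000 nM, with an estimated range from 7000 nM to 40000 nM.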

Compound 3, half-maximal inhibitory concentration: 25700 nM
For compound 3 the middle estimate is 1.5-fold (0.18 log units) below the measured one; the measured number falls inside the stated range.
By their numbers in this assay, from the lowest: compounds 2, 1 and 3 (each within the scatter of the next).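

In this assay, 3,4,5-trimethoxyphenyl in place of 4-methoxyphenyl gives a 1.2-fold higher number from compound 1 to compound 3 (0.09 log units; within the scatter) and 3,4,5-trimethoxyphenyl in place of 4-aminophenyl gives a 1.8-fold higher number from compound 2 to compound 3 (0.25 log units; within the scatter) on the same carbonyl carbon. All three aromatic groups tried at this position therefore lie within the scatter of one another, so the added methoxy groups produce no readable shift. The data offer no explanation for this. Still open, from the compounds shown here alone, is whether a carboxylic acid on the aromatic ring would move the number beyond the scatter. A plain alkyl chain in place of the ring is equally untested here.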